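A Pyridinyl Arm in Place of a Hydroxyl Chain

The compounds below may be only part of what the source reports. "The series", "measured", "known", "first", "only" and "open" are said of these compounds alone.

Compound 1 `C/C(=N\CCO)c1c(O)c2ccccc2oc1=O`: 92000 nM
Compound 2 `CCCC/N=C(\C)c1c(O)c2ccccc2[nH]c1=O`: >= 100000 nM

Of the compounds shown here, two have so far been tested in an assay on isolated protein for inhibition of myosin-2 (Bos taurus), read by spectrophotometry, with a stated time of 24 min; on this read-out higher numbers stand for weaker inhibition and lower numbers for stronger inhibition. Compound 1 gives 92000 nM, and this is the only actual number shown, so compound 1 stands as the one compound with a measured value, and a weak inhibitor at that. Compound 2 gives >= 100000 nM, which is a limit of the assay rather than a number (the limit of >= 100000 nM in this assay, at which 1 of the 2 values shown sits).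

Compound 3 `C/C(=N\Cc1ccccn1)c1c(O)c2ccccc2oc1=O` differs from compound 1 in a single place: pyridin-2-yl in place of hydroxymethyl on a saturated chain carbon bound to a double-bonded nitrogen. Within the data shown here, no step between measured compounds exists to show how such a change plays out, so the size of the step can only be guessed. The expected step of a 1.5-fold lower number from compound 1 to compound 3 (0.19 log units; within the scatter) is a modest move toward stronger inhibition, hardly beyond the scatter. Compound 3 is therefore estimated at 60000 nM, with a likely range from 15000 nM to 250000 nM.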

Compound 3, half-maximal inhibitory concentration: 22000 nM
Compound 3: the middle estimate sits 2.7-fold (0.44 log units) above what was measured; measured number inside the range.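

Among these compounds, putting pyridin-2-yl in place of hydroxymethyl on a saturated chain carbon bound to a double-bonded nitrogen gives the first readable step in this assay: a 4.2-fold lower number from compound 1 to compound 3 (0.62 log units; beyond the scatter). This place therefore responds to change and can carry a six-membered aromatic ring without any loss of inhibition. The incoming group has no hydrogen-bond donor, so in this one pair the donor of hydroxymethyl is not needed, but nothing measured here explains why the number falls.

A single pair cannot separate the effect of the ring from that of its nitrogen, and a phenyl ring or a longer chain ending in pyridin-2-yl at this place would address that question. On these data alone, compound 2 gives >= 100000 nM, a limit and not a number, so whether this arm would act in the same way on its core also stays open.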